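From Ethyl to Isopropyl at a Cytotoxicity Limit

A few compounds are considered here, and "the series" means these few. Any claim that something is new, unique, unknown or untested is made for them only; others in the source may bear on it.

Compound 1 `CCc1ccc(-c2nc3c(c(C)nn3-c3ccccc3)c(-c3ccccc3O)c2C#N)cc1` was measured in an ADME assay on BJ cells (Homo sapiens) for cytotoxicity, with a stated time of 72 h; on this read-out higher numbers stand for an effect only at larger amounts of compound and lower numbers for an effect already at smaller amounts. In this assay compound 1 reads > 20000 nM, which is a limit and not a number. Compound 2 `CCc1ccc(-c2nc3c(c(C)nn3-c3ccccc3)c(-c3ccccc3OC(F)(F)F)c2C#N)cc1` reads > 20000 nM, also a limit. Compound 3 `CCc1ccc(-c2nc3c(c(C)nn3-c3ccccc3)c(-c3ccc(O)cc3)c2C#N)cc1` reads > 20000 nM, again a limit. Together the three compounds give one picture: the limit of > 20000 nM in this assay, at which 3 of the 3 values shown sit.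

Compound 4 `Cc1nn(-c2ccccc2)c2nc(-c3ccc(C(C)C)cc3)c(C#N)c(-c3ccccc3O)c12` departs from compound 1 by a single change, (methyl in place of hydrogen on a saturated chain carbon bound to an aromatic carbon and a saturated chain carbon). In words, methyl takes the place of hydrogen on a saturated chain carbon bound to an aromatic carbon and a saturated chain carbon, turning ethyl into isopropyl.

Three measured steps exist: a step that the two limits leave unreadable from compound 1 to compound 2, a step that the two limits leave unreadable from compound 1 to compound 3 and a step that the two limits leave unreadable from compound 2 to compound 3. None has a readable size, and none touches the ethyl group, so they offer no direct measure of this change. The expectation therefore rests on the starting point, compound 1 at > 20000 nM, a limit. No step beyond the scatter is expected in this assay, and no direction can be assigned, with another limit reading the likeliest outcome. The expected step is a number no higher from compound 1 to compound 4 (the limit leaves the size open). For compound 4 the estimated value is 20000 nM, with an expected range from 11000 nM to 30000 nM.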

Compound 4, half-maximal effective concentration: 22600 nM
The estimate for compound 4 lay 1.1-fold (0.05 log units) below the measured number; the range from low to high includes it.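

The step from compound 1 to compound 4, ethyl to isopropyl, cannot be read in this assay: compound 1 is known only as a limit, so no size can be given. The compounds shown leave open how large the effect of this change on the read-out is, and in which direction it runs.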